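Swapping Cyclopropylmethyl for Tert-Butyl in Compound 3

The source may hold more compounds than are shown below. What is called first, only, known or untested is meant among the compounds shown, and "the series" means these compounds.

Compound 2 `CS(=O)(=O)c1ccc(Nc2ncnc(N3CCC(c4nc(CC5CC5)no4)CC3)c2[N+](=O)[O-])cc1` gives 160 nM in a functional assay for agonist activity at Glucose-dependent insulinotropic receptor (Homo sapiens) (a lower number here means that less compound is needed, a higher number that more compound is needed for the effect), while compound 1 `Cc1noc(C2CCN(c3ncnc(Nc4ccc(S(C)(=O)=O)cc4)c3[N+](=O)[O-])CC2)n1` gives 260 nM; the two values lie within the scatter of each other, so neither stands apart. Compound 3 `CC(C)(C)c1noc(C2CCN(c3ncnc(Nc4ccc(S(C)(=O)=O)cc4)c3[N+](=O)[O-])CC2)n1` differs from compound 2 by tert-butyl in place of cyclopropylmethyl on an aromatic carbon. Going by the values given here, the only measured step that bears on this position, a 1.6-fold lower number from compound 1 to compound 2 (0.21 log units; within the scatter), stayed within the scatter. A step of similar size is therefore expected in this assay, a 1.2-fold higher number from compound 2 to compound 3 (0.07 log units; within the scatter), with no move beyond the scatter in either direction. Compound 3 is estimated at 190 nM, with a range from 80 nM to 450 nM.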

Compound 3, half-maximal effective concentration: 1.5 nM
For compound 3 the middle estimate is 130-fold (2.10 log units) above the measured one; the whole stated range lies above it.
By their numbers in this assay, from the lowest: compound 3; then compounds 2 and 1 (each within the scatter of the next).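

In this assay the group on this aromatic carbon matters far more than methyl and cyclopropylmethyl suggested, since tert-butyl brings a 110-fold lower number from compound 2 to compound 3 (2.03 log units; beyond the scatter) and a 170-fold lower number from compound 1 to compound 3 (2.24 log units; beyond the scatter) as well. Cyclopropylmethyl and tert-butyl have the same carbon count, so that count alone does not decide the outcome here; what sets them apart is that tert-butyl has no ring. Nothing at hand accounts for this large step.

Going by these compounds, whether isopropyl or cyclobutyl would keep a number close to that of compound 3 remains open. So does the outcome with an amine on this carbon.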